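Adding a Methoxyethoxy Chain to Compound 1

The compounds below may be only part of what the source reports. "The series", "measured", "known", "first", "only" and "open" are said of these compounds alone.

Compound 1, `Cc1ccc2ccc(-c3cccc(C#N)c3)cc2n1`, is the reference point of this small set. For the measured compounds named here, in a functional assay on CHO cells for inhibition of metabotropic glutamate receptor 5 (Rattus norvegicus), read by FLIPR and calcium flux (a lower number here means a stronger inhibitor, a higher number a weaker inhibitor), compound 1 gives 7.7 nM, the lowest of the two numbers known here. Compound 2, `Cc1ccc2ccc(-c3cccc(O)c3)cc2n1`, carries a hydroxy in place of the cyano on the aromatic carbon and gives 19000 nM in this assay; the step is a 2500-fold higher number from compound 1 to compound 2 (3.39 log units; beyond the scatter). Compound 3, `Cc1ccc2ccc(-c3cccc(C(F)(F)F)c3)cc2n1`, carries a trifluoromethyl in the same place. For compound 3 this assay reports only a limit, > 10000 nM. The step is an at least 1200-fold higher number from compound 1 to compound 3 (3.11 log units; beyond the scatter), while the step that the limit leaves unreadable from compound 2 to compound 3 cannot be sized because of the limit of > 10000 nM in this assay, at which 1 of the 3 values shown sits.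

Compound 4, `COCCOc1cc(C#N)cc(-c2ccc3ccc(C)nc3c2)c1`, differs from compound 1 by 2-methoxyethoxy in place of hydrogen on an aromatic carbon. The cyano of compound 1 is kept. Neither measured step bears directly on this change: both replace the cyano itself, whereas compound 4 keeps it and adds a chain on another aromatic carbon. Going by the values given here, the two measured steps show only that the strong number of compound 1 rests on the cyano. Nothing known here sizes the effect of the added 2-methoxyethoxy, so a modest weakening is expected rather than a large one. The estimate for compound 4 is 30 nM, between 6 nM and 200 nM, which is expected to mean a 3.9-fold higher number from compound 1 to compound 4 (0.59 log units; beyond the scatter).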

Compound 4, half-maximal inhibitory concentration: 82 nM
Compound 4: the middle estimate sits 2.7-fold (0.44 log units) below what was measured; low and high end bracket the measured number.
By their numbers in this assay, from the lowest: compound 1; then compound 4; then compound 2.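

In this assay, for the compounds shown here, 2-methoxyethoxy in place of hydrogen on this aromatic carbon, meta to a cyano group, gives an 11-fold higher number from compound 1 to compound 4 (1.03 log units; beyond the scatter), so a position that the earlier steps left untouched does respond to substitution. Unlike those steps, which replaced the cyano itself, this change keeps the cyano and adds a chain elsewhere on the same ring, and the position accepts that chain at a clear cost without losing inhibition altogether: compound 4 gives 82 nM. Nothing shown here gives a cause for this step.

With a single group at this position, the compounds shown do not tell whether the loss belongs to the whole chain, to its far end, or to the oxygen attached directly to the ring. A plain methoxy, a longer polyether chain, an amine or a carboxylic acid on the same aromatic carbon, with the cyano kept, would show how the number in this assay follows the length and the end group of what is placed there.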